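This account rests on a few compounds, and the source may have more. Where it says the series, first, only, none or still open, it means among the compounds named here.

Compound 3 `COc1cc2c(cc1OC)C(CC(=O)N1CCCCC1)CC2` holds the second highest of three numbers in a functional assay on the whole organism (strain Wistar) for inhibition, with Rattus norvegicus as the target, read by paw edema, with stated times of 60 min and 1 h, at a dose of 100 mg/kg by the oral route (a higher number here means more inhibition at the dose given (going by the name of the read-out), a lower number less inhibition), where compound 3 gives 18.8%; its nearest neighbour compound 1 `CNC(=O)CC1CCc2cc(OC)c(OC)cc21` gives 15.6%, a gap within the scatter, while compound 2 `COc1cc2c(cc1OC)C(CC(=O)NC(C)(C)C)CC2` gives 31.3%. Two measured steps end at it: a number 3.2 percentage points higher from compound 1 to compound 3 (within the scatter) and a number 12.5 percentage points lower from compound 2 to compound 3 (beyond the scatter). Compound 4 `COc1cc2c(cc1OC)C(CC(=O)N1CCNCC1)CC2` differs from compound 3 in one place: piperazin-1-yl in place of piperidin-1-yl on a carbonyl carbon. Among the compounds with values here, no measured step swaps one saturated ring for another on this carbonyl, and the amide changes seen so far moved the read-out by modest amounts at most, so the step expected for compound 4 is a number 1.2 percentage points higher from compound 3 to compound 4 (within the scatter), essentially none beyond the scatter. Compound 4 is therefore estimated at 20%, within 8% to 33%.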

Compound 4, a percentage reported as inhibition, in the whole organism at one dose (the size of the read-out at that dose, not a potency): 62.5%
For compound 4 the middle estimate is 42.5 percentage points below the measured one, outside the stated range (above it).
By their numbers in this assay, from the lowest: compounds 1 and 3 (each within the scatter of the next); then compound 2; then compound 4.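

In this assay, within the data shown here, this carbonyl carbon proves far more sensitive to the amine part than the earlier compounds showed: exchanging one six-membered non-aromatic ring for another gives a number 43.7 percentage points higher from compound 3 to compound 4 (beyond the scatter), the largest step so far. The piperazin-1-yl amide also clears the (tert-butyl)amino amide, with a number 31.2 percentage points higher from compound 2 to compound 4 (beyond the scatter), and the methylamino amide, with a number 46.9 percentage points higher from compound 1 to compound 4 (beyond the scatter), which places compound 4 highest of the four. No evidence at hand accounts for this jump. The compounds shown leave open whether the gain needs the ring's free amine hydrogen, which a morpholine ring or a piperazine with a methyl group on that nitrogen would test.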